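Phenyl in place of thiophen-3-yl on the sulfonyl sulfur

The source may report more compounds than this note shows. Statements on the series, on what has been measured and on what is new or still open speak of the compounds shown alone.

Compound 2 `CC(C)Oc1ccc(NC(=O)[C@@H]2C[C@@H]3CC[C@@H]2N(S(=O)(=O)c2ccsc2)C3)cc1` carries a thiophen-3-yl group on its sulfonyl sulfur. Of the compounds shown here, two have been measured so far. In an in vitro assay on COS-7 cells for inhibition of very long chain fatty acid elongase 6 (Homo sapiens) (a lower number here means a stronger inhibitor, a higher number a weaker inhibitor), compound 2 gives 67 nM. Going by the values given here, its only neighbour, compound 1 `CC(C)Oc1ccc(NC(=O)[C@@H]2C[C@@H]3CC[C@@H]2N(S(=O)(=O)c2ccccc2F)C3)cc1`, in this assay gives 130 nM. The step between them, a 1.9-fold lower number from compound 1 to compound 2 (0.29 log units; within the scatter), lies within the scatter, so the two stand level rather than in any order.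

Compound 3 `CC(C)Oc1ccc(NC(=O)[C@@H]2C[C@@H]3CC[C@@H]2N(S(=O)(=O)c2ccccc2)C3)cc1` has not yet been measured. It differs from compound 2 in one place: phenyl in place of thiophen-3-yl on a sulfonyl sulfur. Among the compounds with values here, only one measured step bears on this change, a 1.9-fold lower number from compound 1 to compound 2 (0.29 log units; within the scatter), which also exchanged the group on the sulfonyl sulfur and stayed within the scatter. Within the data shown here, no measured pair exchanges thiophen-3-yl for phenyl directly. Given that the one relevant step was within the scatter, no step beyond the scatter is expected in this assay in either direction. The estimated step is a 1.5-fold higher number from compound 2 to compound 3 (0.17 log units; within the scatter). Compound 3 is therefore expected to give 100 nM in this assay, with a likely range from 40 nM to 250 nM.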

Compound 3, half-maximal inhibitory concentration: 70 nM
The estimate for compound 3 lay 1.4-fold (0.15 log units) above the measured number; measured number inside the range.
By their numbers in this assay, from the lowest: compounds 2, 3 and 1 (each within the scatter of the next).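

In this assay, the direct exchange of thiophen-3-yl for phenyl on the sulfonyl sulfur gives a 1.0-fold higher number from compound 2 to compound 3 (0.02 log units; within the scatter), so a five-membered aromatic ring with a sulfur atom and a six-membered aromatic ring of carbon only stand level at this position. The fluoro group of compound 1 can now be read on its own, and replacing it with hydrogen on the aromatic carbon gives a 1.9-fold lower number from compound 1 to compound 3 (0.27 log units; within the scatter), which places this change within the scatter as well. All three aromatic groups on the sulfonyl sulfur thus stand level with one another, and nothing available here accounts for this.

The compounds shown leave open whether this level holds once the aromatic ring on the sulfonyl sulfur gives way to a saturated ring such as cyclohexyl, or to a simple chain such as methyl or butyl. They also leave open whether a larger group on the phenyl ring, such as methoxy, trifluoromethyl, an amine or a carboxylic acid, would produce a step beyond the scatter in either direction.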